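Adding Chloro to the Sulfonyl Aryl Ring of Compound 2

This account rests on a few compounds, and the source may have more. Where it says the series, first, only, none or still open, it means among the compounds named here.

Measured so far:
compound 1 `COc1ccc(S(=O)(=O)c2cnc3cc(Cl)ccc3c2N2CCC(C)CC2)cc1Cl` gives 93% in an assay on isolated protein for displacement of a labelled ligand from metabotropic glutamate receptor 5 (Homo sapiens), with a stated time of 60 min, tested at 1 uM; on this read-out higher numbers stand for more inhibition at the one concentration tested (going by the name of the read-out) and lower numbers for less inhibition
compound 2 `Cc1ccc(S(=O)(=O)c2cnc3cc(Cl)ccc3c2N2CCC(C)CC2)cc1` gives 94% in this assay

Compound 2 has the higher of the two numbers, but the step between them is a number 1 percentage points higher from compound 1 to compound 2 (within the scatter), so the two compounds cannot be told apart on these data. Both displace almost all of the labelled ligand at the single concentration tested.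

Compound 3 `Cc1ccc(S(=O)(=O)c2cnc3cc(Cl)ccc3c2N2CCC(C)CC2)cc1Cl` has not yet been measured. It differs from compound 2 in one place: chloro in place of hydrogen on an aromatic carbon. Going by the values given here, the only measured step that touches this part of the molecule is the change from compound 1 to compound 2, which swapped 3-chloro-4-methoxyphenyl for 4-methylphenyl and gave a number 1 percentage points higher from compound 1 to compound 2 (within the scatter). That step removed a chloro group together with a change from methoxy to methyl, and the number barely moved. Compound 3 puts a chloro group back while keeping the methyl, so the new compound sits between the two measured ones in structure.

On that basis no step beyond the scatter is expected for compound 3, with an estimated change of a number 1 percentage points lower from compound 2 to compound 3 (within the scatter). Compound 3 is estimated at 93%, in the range 85% to 99%.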

Compound 3, a percentage reported as inhibition, at one concentration (the size of the read-out at that concentration, not a potency): 89%
The estimate for compound 3 lay 4 percentage points above the measured number; low and high end bracket the measured number.
By their numbers in this assay, from the lowest: compounds 3, 1 and 2 (each within the scatter of the next).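

Going by these compounds alone, putting a chloro group on the aromatic carbon ortho to the methyl group, the change from 4-methylphenyl to 3-chloro-4-methylphenyl, gives in this assay a number 5 percentage points lower from compound 2 to compound 3 (within the scatter) and so shows that this position carries a chloro group with no step that stands out from the scatter. With that chloro group held constant, methyl in place of methoxy gives a number 4 percentage points lower from compound 1 to compound 3 (within the scatter) and so reads this swap on its own, whereas the earlier step from compound 1 to compound 2 changed the methoxy group and the chloro group together. No measurement at hand bears on why these numbers fall where they do.

All three compounds give similar numbers at one concentration, which leaves open whether they would also match in a full potency measurement. On these data alone, it also remains open how this position would respond to a group other than chloro, such as an amine, a carboxylic acid or a longer chain.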